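Bromo in Place of Cyano: Expected Half-Life

A few compounds are considered here, and "the series" means these few. Any claim that something is new, unique, unknown or untested is made for them only; others in the source may bear on it.

Measured so far:
compound 1 `C[C@H](CSc1nonc1/C(=N/O)Nc1ccc(F)c(Br)c1)NC(=O)CS(N)(=O)=O`: 1.33 h
compound 2 `N#Cc1cc(N/C(=N\O)c2nonc2SCCNC(=O)CS(N)(=O)=O)ccc1F`: > 3 h

In an ADME assay on isolated protein for pharmacokinetics, with UDP-glucuronosyltransferase 1A9 (Homo sapiens) as the target, read by LC-MS, with a stated time of 60 min, at 37 degrees C, tested at 1 uM, in the presence of a further agent that is not named here (a lower number here means that the compound disappears faster, a higher number that the compound lasts longer), compound 2 gives > 3 h, which is a limit of the assay rather than a number. Compound 2 sits at the limit of > 3 h in this assay, at which 1 of the 2 values shown sits. Compound 1 gives 1.33 h in this assay. Compound 3 `NS(=O)(=O)CC(=O)NCCSc1nonc1/C(=N/O)Nc1ccc(F)c(Br)c1` has not yet been measured; it differs from compound 2 by bromo in place of cyano on an aromatic carbon. Since compound 2 stands only at a limit, the step of an at least 1.5-fold lower number from compound 2 to compound 3 (0.17 log units; that floor lies within the scatter) is expected to be downward, possibly beyond the scatter. Compound 3 is estimated at 2 h, with a likely range from 1 h to 4 h.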

Compound 3, half-life: 0.758 h
Estimate against measurement, compound 3: 2.6-fold (0.42 log units) above; measured number outside the range, below it.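

In this assay, the change from 3-cyano-4-fluorophenyl to 3-bromo-4-fluorophenyl gives an at least 3.9-fold lower number from compound 2 to compound 3 (0.59 log units; beyond the scatter), so the group at this place on the ring clearly matters for half-life. Compound 2 carries a limit of the assay rather than a number, so the true step may be larger. Removing the chain methyl gives a 1.8-fold lower number from compound 1 to compound 3 (0.24 log units; within the scatter), which stays within the scatter, so no effect of that methyl can be read alongside the bromo group. On these data alone, whether a chloro, amino or carboxylic acid group at this place would give a half-life nearer that of the nitrile remains open. As far as these compounds go, whether the chain methyl matters alongside the nitrile also remains open.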